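Chloro in place of nitro, a step made twice

The compounds below may be only part of what the source reports. "The series", "measured", "known", "first", "only" and "open" are said of these compounds alone.

Compound 1 `COc1ccc(-c2cc(-c3ccc(Cl)cc3)nc(NC(=O)N/N=C\c3ccccc3Cl)n2)c(OC)c1` — in a functional assay on the whole organism (strain Albino) with Mus musculus as the target, with a stated time of 4 h (a lower number here means that less compound is needed, a higher number that more compound is needed for the effect), compound 1 gives 300 mg/kg.
Compound 2 `COc1ccc(-c2cc(-c3ccc(Cl)cc3)nc(NC(=O)N/N=C\c3ccccc3[N+](=O)[O-])n2)c(OC)c1` — in this assay compound 2 gives 300 mg/kg.
Compound 3 `C/C(=N/NC(=O)Nc1nc(-c2ccc(C)cc2)cc(-c2ccc(Cl)cc2)n1)c1ccc([N+](=O)[O-])cc1` — in this assay compound 3 gives 300 mg/kg.

Compounds 1 and 2 share one core and differ only by chloro in place of nitro on an aromatic carbon. That exchange made the step of no change at the digits printed from compound 2 to compound 1 (within the scatter), so the two values stand together within the scatter. Compound 3 rests on a different core; the difference between the two cores is not broken down here, and its value stands level with those of compounds 1 and 2.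

Compound 4 `C/C(=N/NC(=O)Nc1nc(-c2ccc(C)cc2)cc(-c2ccc(Cl)cc2)n1)c1ccc(Cl)cc1` has not yet been measured in this assay. It differs from compound 3 by chloro in place of nitro on an aromatic carbon. Among the measured compounds shown here, this is the same kind of change as the one from compound 2 to compound 1, though not the same: in the earlier pair the chloro sits ortho to a large group, here it sits para to a large group. Because the earlier exchange gave no change at the digits printed from compound 2 to compound 1 (within the scatter), the step from compound 3 to compound 4 is expected to be no change at the digits printed from compound 3 to compound 4 (within the scatter). Compound 4 is therefore estimated to give 300 mg/kg, expected to lie between 150 mg/kg and 600 mg/kg.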

Compound 4, dose for half-maximal effect: 300 mg/kg
Compound 4: the middle estimate sits on the measured number at the digits printed; the measured number falls inside the stated range.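

In this assay, chloro in place of nitro, here para to a large group, gave no change at the digits printed from compound 3 to compound 4 (within the scatter). Set beside the earlier pair, the exchange carried from one core to the other with no visible difference between the two steps: the same change on two cores in this assay, no change at the digits printed (within the scatter) from compound 2 to compound 1 and no change at the digits printed (within the scatter) from compound 3 to compound 4, 1.0-fold (0.00 log units) apart, within the scatter of two such steps. This shows that, on these two cores and at the two places involved, swapping nitro for chloro left the dose where it stood, but with all four compounds level it does not show that the exchange would transfer just as well in a case where it moved the value by a real amount.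

The compounds shown leave open what a different group at this place on the aromatic ring would do, such as an amine, a carboxylic acid or a longer alkyl chain in place of nitro or chloro. From the compounds shown here alone, it also remains open whether the same exchange would read alike on any core other than these two.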